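The source may hold more compounds than are shown below. What is called first, only, known or untested is meant among the compounds shown, and "the series" means these compounds.

Measured so far:

Compound 1 `CCN(CC)c1ccc2cc(C(=O)c3ccc(N4CCN(C(=O)CN5CCN(S(=O)(=O)c6ccc(C#N)cc6)CC5)CC4)cc3)oc2c1` — in a functional assay on HCT-116 cells (Homo sapiens) for cytotoxicity, read by MTT assay, with a stated time of 48 h (a lower number here means a stronger inhibitor, a higher number a weaker inhibitor), compound 1 gives 36400 nM
Compound 2 `C#CCN1CCN(CC(=O)N2CCN(c3ccc(C(=O)c4cc5ccc(N(CC)CC)cc5o4)cc3)CC2)CC1` — compound 2 gives 17700 nM
Compound 3 `CCOC(=O)CN1CCN(CC(=O)N2CCN(c3ccc(C(=O)c4cc5ccc(N(CC)CC)cc5o4)cc3)CC2)CC1` — for compound 3 only a limit of the assay is known, > 40000 nM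

Compound 3 therefore stands at the edge of what this assay reports: its value is a limit and not a number (the limit of > 40000 nM in this assay, at which 1 of the 3 values shown sits). The steps that reach it are an at least 1.0-fold higher number from compound 1 to compound 3 (0.04 log units; that floor lies within the scatter) and an at least 2.2-fold higher number from compound 2 to compound 3 (0.35 log units; beyond the scatter); the first has a floor that lies within the scatter, the second is at least modest. Both steps exchange the group on the amine nitrogen in the ring, and in both compound 3 ends up with the weakest reading that the assay can give.

Compound 4 `CCN(CC)c1ccc2cc(C(=O)c3ccc(N4CCN(C(=O)CN5CCN(CC(C)=O)CC5)CC4)cc3)oc2c1` differs from compound 3 by methyl in place of ethoxy on a carbonyl carbon whose other neighbour is a saturated chain carbon. Going by the values given here, no measured step exchanges a group at this carbonyl carbon, so the measured steps bear on it only indirectly: they show that compound 3 sits at the limit, and a change this small gives no ground to expect a move beyond the scatter. Compound 4 is therefore expected to give about 40000 nM, between 15000 nM and 80000 nM, a step of a number no higher from compound 3 to compound 4 (the limit leaves the size open) that is expected to stay within the scatter.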

Compound 4, half-maximal inhibitory concentration: 24000 nM
Estimate against measurement, compound 4: 1.7-fold (0.22 log units) above; the measured number falls inside the stated range.
By their numbers in this assay, from the lowest: compounds 2, 4 and 1 (each within the scatter of the next, the first and the last beyond it). At a limit, above all of these: compound 3.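

With methyl in place of ethoxy on a carbonyl carbon, this position now has a measured number, whereas compound 3 offers only a limit, so the full size of the change stays open: the limit of > 40000 nM in this assay, at which 1 of the 4 values shown sits.

In this assay the change is an at least 1.6-fold lower number from compound 3 to compound 4 (0.22 log units; that floor lies within the scatter), so it is not shown to exceed the scatter. Going by these compounds alone, the new compound also falls within the scatter of both earlier measured neighbours, which the earlier compounds could not show for this group: the comparison with the propargyl compound is a 1.4-fold higher number from compound 2 to compound 4 (0.13 log units; within the scatter), with acetyl in place of ethynyl on a saturated chain carbon, and the comparison with the sulfonyl compound is a 1.5-fold lower number from compound 1 to compound 4 (0.18 log units; within the scatter), with 2-oxopropyl in place of (4-cyanophenyl)sulfonyl on the amine nitrogen in the ring.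

The compounds shown leave open how the number would respond to an amine or a carboxylic acid on this carbonyl carbon, or to a longer chain in place of methyl. All four compounds share one core, so they also leave open whether these small differences would hold on any other core.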